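A Halogen Swap Repeated at a Second Position

This account rests on a few compounds, and the source may have more. Where it says the series, first, only, none or still open, it means among the compounds named here.

Compound 1 `COc1ccc2nc(NC(=O)c3cn(-c4ccccc4)nc3-c3ccc(F)cc3)sc2c1` was tested in a functional assay on U-87MG ATCC cells for cytotoxicity against U-87 MG (Homo sapiens), read by MTT assay, with a stated time of 72 h; a lower number here means a stronger inhibitor, a higher number a weaker inhibitor. In this assay compound 1 gives > 50000 nM, which is a limit of the assay rather than a number. Compound 2 `COc1ccc2nc(NC(=O)c3cn(-c4ccccc4)nc3-c3ccc(Cl)cc3)sc2c1` differs from it by chloro in place of fluoro on an aromatic carbon, and in this assay compound 2 gives 21200 nM, a step of an at least 2.3-fold lower number from compound 1 to compound 2 (0.37 log units; beyond the scatter). Compound 3 `COc1ccc(-c2nn(-c3ccccc3)cc2C(=O)Nc2nc3ccc(F)cc3s2)cc1` holds the same atoms as compound 1 joined differently; the difference between the two cores is not broken down here. In this assay compound 3 gives 8990 nM, the lowest number among the measured pair. Compound 4 `COc1ccc(-c2nn(-c3ccccc3)cc2C(=O)Nc2nc3ccc(Cl)cc3s2)cc1` differs from compound 3 by chloro in place of fluoro on an aromatic carbon. The place of this change is now part of a fused system of two rings, meta to a fused ring and para to a fused ring, rather than para to a large group. This is the same kind of change, not the same one. Resting on the step from compound 1 to compound 2 of an at least 2.3-fold lower number from compound 1 to compound 2 (0.37 log units; beyond the scatter), a step of a 2.0-fold lower number from compound 3 to compound 4 (0.30 log units; within the scatter) is expected. Compound 4 is thus estimated at 4500 nM in this assay.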

Compound 4, half-maximal inhibitory concentration: 8710 nM
For compound 4 the middle estimate is 1.9-fold (0.29 log units) below the measured one; the range from low to high includes it.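

On the core of compound 3, 6-chloro-1,3-benzothiazol-2-yl in place of 6-fluoro-1,3-benzothiazol-2-yl gives a 1.0-fold lower number from compound 3 to compound 4 (0.01 log units; within the scatter) in this assay, so the step beyond the scatter seen on the core of compound 1 does not recur in this pair. Set side by side, the two steps cannot be said to differ: the same change on two cores in this assay, an at least 2.3-fold lower number (0.37 log units; beyond the scatter) from compound 1 to compound 2 and a 1.0-fold lower number (0.01 log units; within the scatter) from compound 3 to compound 4; the limit leaves it open whether they differ Compound 1 gives > 50000 nM, which is a limit of the assay and not a number, and two pairs changed at different places give no general rule for this series: the limit of > 50000 nM in this assay, at which 1 of the 4 values shown sits.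

The compounds shown leave open what bromo, an amine or a carboxylic acid at the same place would give in this assay. They also leave open whether the chloro and fluoro pair would behave alike on further cores.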